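Hydroxyguanidine hydrazones: methyl for chloro, cytotoxicity outlook

The compounds below may be only part of what the source reports. "The series", "measured", "known", "first", "only" and "open" are said of these compounds alone.

Working notes on a small set of aryl hydrazone hydroxyguanidines tested in an ADME assay on HeLa cells (Homo sapiens) for cytotoxicity; on this read-out higher numbers stand for lower toxicity in this test and lower numbers for higher toxicity in this test. Compound 1 `N=C(NO)N/N=C/c1ccc(Cl)cc1` gives only a limit of the assay, > 100000 nM, in this assay, so no number marks where it stands. Compound 2 `COc1ccccc1/C=N/N=C(\N)NO` likewise returns a limit, > 100000 nM, in this assay. Compound 3 `N/C(=N\O)N/N=C/c1ccccc1O` also returns a limit, > 100000 nM, in this assay. Within the data shown here, every measured member of the set thus sits at the same limit (the limit of > 100000 nM in this assay, at which 3 of the 3 values shown sit), and no step between measured compounds can be counted.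

Compound 4 `Cc1ccc(/C=N/NC(=N)NO)cc1` has not been measured in this assay. It differs from compound 1 by methyl in place of chloro on an aromatic carbon. With all three measured values at the limit (the limit of > 100000 nM in this assay, at which 3 of the 3 values shown sit), the expectation is that compound 4 returns no number either, and any step from compound 1 is expected to lie within the scatter rather than in a set direction. The estimate for compound 4 in this assay is 150000 nM, with a range of 60000 nM to 400000 nM. The step this estimate implies, a step that the limit leaves unreadable from compound 1 to compound 4, is expected to be none beyond the scatter.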

Compound 4, half-maximal cytotoxic concentration: > 100000 nM
Compound 4 ended at the assay's limit; the forecaster's own chance of this, stated with the estimate: 85%; the middle value does not contradict the limit.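

Among these compounds, compound 4, like compound 1, returns only a limit in this assay, so no step from compound 1 to compound 4 can be read: the limit of > 100000 nM in this assay, at which 4 of the 4 values shown sit. The compounds shown leave open at what concentration any of them turns cytotoxic in this assay, and whether methyl in place of chloro on an aromatic carbon matters.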